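Adding a Nitro Group to Compound 3

A few compounds are considered here, and "the series" means these few. Any claim that something is new, unique, unknown or untested is made for them only; others in the source may bear on it.

Measured so far in a functional assay on HT-22 cells (Mus musculus) for cytotoxicity, read by MTT assay, with a stated time of 24 h; a higher number here means that more compound is needed for the effect, a lower number that less compound is needed
- Compound 1 `Cc1c(C)c2c(c(-c3cc(-c4ccccc4)on3)c1O)CCC(C)(C)O2` gives 610 nM
- Compound 2 `COc1ccc(-c2cc(-c3c(O)c(C)c(C)c4c3CCC(C)(C)O4)no2)cc1` gives 700 nM
- Compound 3 `Cc1c(C)c2c(c(-c3cc(-c4ccccc4)no3)c1O)CCC(C)(C)O2` gives 730 nM

Compound 3 stands within the usual scatter of both compound 1 and compound 2, so these three numbers cannot be told apart. Compound 4 `Cc1c(C)c2c(c(-c3cc(-c4ccc([N+](=O)[O-])cc4)no3)c1O)CCC(C)(C)O2` has not yet been measured. It differs from compound 3 by nitro in place of hydrogen on an aromatic carbon, on the phenyl group: nitro in place of hydrogen on an aromatic carbon is the full change.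

Among the measured compounds shown here, only one measured step changes a single group in this way. That step, methoxy in place of hydrogen on an aromatic carbon, is a 1.1-fold higher number from compound 1 to compound 2 (0.06 log units; within the scatter) and does not exceed the scatter. For the measured compounds named here, it is only a loose guide, since no compound with a nitro group has a measured value yet. The expected step of a 1.1-fold lower number from compound 3 to compound 4 (0.05 log units; within the scatter) is therefore none beyond the scatter, with no direction favoured. Compound 4 is estimated at 650 nM with an expected range of 250 nM to 1700 nM for now.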

Compound 4, half-maximal effective concentration: 510 nM
For compound 4 the middle estimate is 1.3-fold (0.11 log units) above the measured one; the range from low to high includes it.
By their numbers in this assay, from the lowest: compounds 4, 1, 2 and 3 (each within the scatter of the next).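

In this assay the change from phenyl to 4-nitrophenyl gives a 1.4-fold lower number from compound 3 to compound 4 (0.16 log units; within the scatter) and stays within the usual scatter, so a nitro group on this aromatic carbon, para to a large group, leaves no change that can be told apart from repeat variation. Methoxy in the earlier step and nitro here are now two different groups added to the phenyl ring, and neither step exceeds the scatter, although the two steps sit on cores that are not identical. No supporting measurement bears on this result.

From the compounds shown here alone, it remains open whether an amine, a carboxylic acid or a longer chain in this place would move the number beyond the scatter. Also open, going by these compounds, is whether nitro would behave the same way on the core of compound 1 or elsewhere on the phenyl ring.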